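From Urea to Amide: Estimating Growth Inhibition for Compound 4

This account rests on a few compounds, and the source may have more. Where it says the series, first, only, none or still open, it means among the compounds named here.

Of the compounds shown here, three sharing one core have been tested in a functional assay on M14 cells (Homo sapiens) for inhibition, read by sulforhodamine B assay, with a stated time of 48 h; a higher number here means a weaker inhibitor of growth, a lower number a stronger inhibitor of growth. Compound 1 `COc1cc(-c2nn(-c3cccc(NC(=O)c4cccc(C(F)(F)F)c4)c3)cc2-c2ccncc2)ccc1Cl` gives 1630 nM. Compound 2 `COc1cc(-c2nn(-c3cccc(NC(=O)Nc4ccc(Cl)c(Cl)c4)c3)cc2-c2ccncc2)ccc1Cl` gives 911 nM, and compound 3 `COc1cc(-c2nn(-c3cccc(NC(=O)Nc4cccc(C(F)(F)F)c4)c3)cc2-c2ccncc2)ccc1Cl` gives 754 nM. Compound 3 has the lowest number of the three, but its gap to compound 2 is within the scatter, since a 1.2-fold lower number from compound 2 to compound 3 (0.08 log units; within the scatter); only against compound 1 is the difference meaningful, with a 2.2-fold lower number from compound 1 to compound 3 (0.33 log units; beyond the scatter).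

Compound 4 `COc1cc(-c2nn(-c3cccc(NC(=O)c4ccc(Cl)c(C(F)(F)F)c4)c3)cc2-c2ccncc2)ccc1Cl` is the next candidate. It differs from compound 3 by 4-chloro-3-(trifluoromethyl)phenyl in place of (3-(trifluoromethyl)phenyl)amino on a carbonyl carbon: the urea becomes an amide. Within the data shown here, the step that bears most directly on this change is the reverse of the one from compound 1 to compound 3, where the amide became a urea and a 2.2-fold lower number from compound 1 to compound 3 (0.33 log units; beyond the scatter); the parallel step where a 1.8-fold lower number from compound 1 to compound 2 (0.25 log units; within the scatter) points the same way. Moving back from urea to amide should therefore raise the number modestly, so for compound 4 the expected step is a 2.0-fold higher number from compound 3 to compound 4 (0.30 log units; within the scatter). Compound 4 is estimated at 1500 nM, within a range of 700 nM to 3200 nM.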

Compound 4, concentration for 50% growth inhibition: 2790 nM
For compound 4 the middle estimate is 1.9-fold (0.27 log units) below the measured one; the measured number falls inside the stated range.
By their numbers in this assay, from the lowest: compounds 3, 2, 1 and 4 (each within the scatter of the next, the first and the last beyond it).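

In this assay, putting 4-chloro-3-(trifluoromethyl)phenyl in place of (3-(trifluoromethyl)phenyl)amino on the carbonyl carbon gives a 3.7-fold higher number from compound 3 to compound 4 (0.57 log units; beyond the scatter), and putting it in place of (3,4-dichlorophenyl)amino gives a 3.1-fold higher number from compound 2 to compound 4 (0.49 log units; beyond the scatter), so this amide sits clearly apart from both ureas. The chloro in place of hydrogen on an aromatic carbon, the only difference between the two amides, gives a 1.7-fold higher number from compound 1 to compound 4 (0.23 log units; within the scatter), so adding it shows no gain in growth inhibition. No measurement is at hand that would explain the gap between the ureas and this amide.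

As far as these compounds go, whether a urea carrying the same 4-chloro-3-(trifluoromethyl)phenyl group would stay close to compound 3 remains open. So does the effect of a methoxy or a nitrile in place of that chloro.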